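The source may hold more compounds than are shown below. What is called first, only, known or untested is meant among the compounds shown, and "the series" means these compounds.

Three compounds have been measured in a functional assay on DU-145 cells (Homo sapiens) for antiproliferative activity, read by MTT assay, with a stated time of 48 h; a lower number here means a stronger inhibitor, a higher number a weaker inhibitor:

Compound 1, `C/C(=C\CC/C(C)=C/CC[C@@H]1[C@@]2(C)CCC(=O)C(C)(C)[C@H]2CC[C@@]1(C)O)CC/C=C(\C)C(=O)OCc1cn(-c2cccc(O)c2)nn1`: 28400 nM
Compound 2, `C/C(=C\CC/C(C)=C/CC[C@@H]1[C@@]2(C)CCC(=O)C(C)(C)[C@H]2CC[C@@]1(C)O)CC/C=C(\C)C(=O)OCc1cn(-c2ccccc2C(F)(F)F)nn1`: > 150000 nM, a limit of the assay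
Compound 3, `COc1cccc(-n2cc(COC(=O)/C(C)=C/CC/C(C)=C/CC/C(C)=C/CC[C@@H]3[C@@]4(C)CCC(=O)C(C)(C)[C@H]4CC[C@@]3(C)O)nn2)c1`: > 150000 nM, a limit of the assay

Among the measured compounds shown here, compound 1 is the only compound with a number; the other two sit at the limit of > 150000 nM in this assay, at which 2 of the 3 values shown sit. Replacing its 3-hydroxyphenyl on the aromatic nitrogen by 2-(trifluoromethyl)phenyl gives an at least 5.2-fold higher number from compound 1 to compound 2 (0.72 log units; beyond the scatter). Putting methyl in place of hydrogen on the oxygen of that ring gives an at least 5.2-fold higher number from compound 1 to compound 3 (0.72 log units; beyond the scatter). Between the two limits, a step that the two limits leave unreadable from compound 2 to compound 3.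

Compound 4, `C/C(=C\CC/C(C)=C/CC[C@@H]1[C@@]2(C)CCC(=O)C(C)(C)[C@H]2CC[C@@]1(C)O)CC/C=C(\C)C(=O)OCc1cn(-c2ccc(F)cc2)nn1`, differs from compound 1 in one place: 4-fluorophenyl in place of 3-hydroxyphenyl on an aromatic nitrogen.

Both measured steps bear on this change, since each alters the 3-hydroxyphenyl of compound 1, and each weakened the compound at least modestly, past the point where a number could be read. A change of the same kind, 4-fluorophenyl in place of 3-hydroxyphenyl, is therefore expected to weaken compound 4 as well, most likely to the same limit. For compound 4 in this assay the expected value is 120000 nM, within a range of 40000 nM to 300000 nM, which means an expected 4.2-fold higher number from compound 1 to compound 4 (0.63 log units; beyond the scatter).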

Compound 4, half-maximal inhibitory concentration: > 150000 nM
Compound 4: no number, only a limit; the forecaster's own chance of this, stated with the estimate: 60%; middle value at least 1.2-fold (0.09 log units) from the limit.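

In this assay, compound 4 also ends at a limit of the assay, > 150000 nM. Replacing 3-hydroxyphenyl with 4-fluorophenyl gives an at least 5.2-fold higher number from compound 1 to compound 4 (0.72 log units; beyond the scatter), so the loss at this position now extends to a third group on the aromatic nitrogen, one that keeps the same number of heavy atoms and the same six-membered aromatic ring but has no hydrogen-bond donor. Among these four compounds, only compound 1 carries a hydroxyl on the phenyl ring, with no compound going against this link, and it alone gives a readable number, while the others share one ceiling: the limit of > 150000 nM in this assay, at which 3 of the 4 values shown sit.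

From the compounds shown here alone, the steps among compound 2, compound 3 and compound 4 cannot be read, so these three groups cannot be ranked, and how much weaker any of them is than compound 1 remains unknown. It also remains open whether the hydroxyl itself is what matters, since the compounds shown do not include a phenyl ring bearing an amine, a carboxylic acid or a hydroxymethyl group at this position.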